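The source may hold more compounds than are shown below. What is called first, only, known or untested is meant among the compounds shown, and "the series" means these compounds.

Compound 1, `CC(c1ccc(-c2ccccc2)c(F)c1)c1nnc2n1N=C(c1ccc(OC(F)(F)F)cc1)CS2`, gives 8400 nM in a functional assay on Huh-7 cells (Homo sapiens) for inhibition, read by sulforhodamine B assay, with a stated time of 72 h; on this read-out higher numbers stand for weaker inhibition and lower numbers for stronger inhibition.
Compound 2, `CC(C)Cc1ccc(C(C)c2n[nH]c(=S)n2N)cc1`, gives 23000 nM in this assay.
Compound 3, `COc1ccc2cc(C(C)c3nnc4n3N=C(c3ccc(Cl)cc3Cl)CS4)ccc2c1`, gives 10700 nM in this assay.

Among these three, compound 1 and compound 3 lie within the scatter of each other, so their two numbers cannot be told apart. Compound 2 stands beyond the scatter from compound 1, with the higher number. Among the compounds with values here, no single-point step between any two of the measured compounds is available, so the effect of any one change has not been seen directly.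

Compound 4, `COc1ccc(C2=Nn3c(nnc3C(C)c3ccc(-c4ccccc4)c(F)c3)SC2)cc1`, differs from compound 1 in one place: methyl in place of trifluoromethyl on an oxygen on an aromatic ring. Within the data shown here, nothing among the measured compounds shows what such an exchange does here. With the shared core unchanged and the rest of the molecule kept, no step beyond the scatter is expected in either direction. This expected step, a 1.2-fold higher number from compound 1 to compound 4 (0.08 log units; within the scatter), is estimated to remain within the usual scatter. Compound 4 is therefore expected to give about 10000 nM in this assay, with a range from 4000 nM to 25000 nM.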

Compound 4, half-maximal inhibitory concentration: 4300 nM
Estimate against measurement, compound 4: 2.3-fold (0.37 log units) above, and the stated range covers the measured number.
By their numbers in this assay, from the lowest: compounds 4, 1 and 3 (each within the scatter of the next, the first and the last beyond it); then compound 2.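

In this assay the change from trifluoromethoxy to methoxy gives the first single-point step among these compounds, a 2.0-fold lower number from compound 1 to compound 4 (0.29 log units; within the scatter), so the two compounds cannot be told apart. Within the data shown here, at this position on the aromatic ring, methyl can thus stand in place of trifluoromethyl on the oxygen without a step beyond the scatter, which the earlier compounds, with no single-point step among them, could not show. Nothing measured here gives a reason for this result.

The compounds shown leave open whether any other group in place of methoxy, such as an amine, a carboxylic acid or a longer alkoxy chain, would give a step beyond the scatter. They also leave open whether the same exchange would give a similar step with a different group on the rest of the molecule.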